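Notes on the step from compound 2 to compound 3

A few compounds are considered here, and "the series" means these few. Any claim that something is new, unique, unknown or untested is made for them only; others in the source may bear on it.

Compound 2 `Brc1ccc(C2=NN(C3=NC(c4ccccc4)CS3)C(c3ccc4ccccc4c3)C2)cc1` gives 13000 nM in a functional assay on BGC-823 cells (Homo sapiens) for inhibition, read by CCK-8 assay, with a stated time of 48 h; on this read-out higher numbers stand for weaker inhibition and lower numbers for stronger inhibition; compound 1 `Cc1ccc(C2=NN(C3=NC(c4ccccc4)CS3)C(c3ccc4ccccc4c3)C2)cc1` gives 8940 nM, and a 1.5-fold higher number from compound 1 to compound 2 (0.16 log units; within the scatter), so the two stand together. Compound 3 `Cc1ccc(C2=NN(C3=NC(c4ccccc4)CS3)C(c3ccc4ccccc4c3)C2)cc1C` differs from compound 2 by 3,4-dimethylphenyl in place of 4-bromophenyl on a carbon with a double bond to nitrogen. For the measured compounds named here, the only step that bears on this change is a 1.5-fold higher number from compound 1 to compound 2 (0.16 log units; within the scatter), which did not leave the scatter, and compound 3 carries the methyl of compound 1 plus one more. The expected step is therefore a 1.4-fold lower number from compound 2 to compound 3 (0.16 log units; within the scatter), nothing beyond the scatter. Compound 3 is estimated at 9000 nM in this assay, with a range of 4000 nM to 20000 nM.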

Compound 3, half-maximal inhibitory concentration: 6570 nM
Compound 3: the middle estimate sits 1.4-fold (0.14 log units) above what was measured; the range from low to high includes it.
By their numbers in this assay, from the lowest: compounds 3, 1 and 2 (each within the scatter of the next).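

In this assay, 3,4-dimethylphenyl in place of 4-bromophenyl gives (a 2.0-fold lower number from compound 2 to compound 3 (0.30 log units; within the scatter)), and the added methyl gives (a 1.4-fold lower number from compound 1 to compound 3 (0.13 log units; within the scatter)). A second methyl on this aromatic ring therefore still leaves the number within the scatter, and the three aryl groups on this carbon with a double bond to nitrogen cannot be told apart. Nothing measured accounts for this flat result. Open, as far as these compounds go, is whether an amine or a carboxylic acid on this ring would move the number beyond the scatter, and what replacing the naphthalen-2-yl group would do.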